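From compound 3 to compound 4: the amine substituent

This account rests on a few compounds, and the source may have more. Where it says the series, first, only, none or still open, it means among the compounds named here.

In a functional assay on NCI-H460 cells (Homo sapiens) for inhibition, read by sulforhodamine B assay, with a stated time of 72 h (on this read-out lower numbers stand for stronger inhibition and higher numbers for weaker inhibition), compound 3 `CCNC(=O)c1nnn(-c2cc(C(C)C)c(O)cc2O)c1-c1ccc(CNCC2CCCCC2)cc1` gives 2.1 nM, the lowest of the three measured numbers, against compound 1 `CCNC(=O)c1nnn(-c2cc(C(C)C)c(O)cc2O)c1-c1ccc(CN(CC)CC)cc1` at 11 nM and compound 2 `CCNC(=O)c1nnn(-c2cc(C(C)C)c(O)cc2O)c1-c1ccc(CN2CCN(C)CC2)cc1` at 47 nM. Compound 4 `CCNC(=O)c1nnn(-c2cc(C(C)C)c(O)cc2O)c1-c1ccc(CNC2CCN(C)CC2)cc1` has 1-methylpiperidin-4-yl in place of cyclohexylmethyl on an amine nitrogen. The closest measured change is the large 22-fold lower number from compound 2 to compound 3 (1.35 log units; beyond the scatter), where (cyclohexylmethyl)amino replaces 4-methylpiperazin-1-yl. The modest steps of a 4.3-fold higher number from compound 1 to compound 2 (0.63 log units; beyond the scatter) and a 5.2-fold lower number from compound 1 to compound 3 (0.72 log units; beyond the scatter) give the same order. Moving away from the cyclohexylmethyl group is therefore expected to raise the number in this assay, by a modest to large step. The estimated change is a 5.7-fold higher number from compound 3 to compound 4 (0.76 log units; beyond the scatter). For compound 4 the expected value is 12 nM, with an estimated range of 3.5 nM to 45 nM.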

Compound 4, half-maximal inhibitory concentration: > 1000 nM
Compound 4: a limit, no number; the forecaster's own chance of this, stated with the estimate: 2%; middle value at least 83-fold (1.92 log units) away from the limit.
By their numbers in this assay, from the lowest: compound 3; then compound 1; then compound 2. At a limit, above all of these: compound 4.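

In this assay compound 4 stands as a limit, not a number: the limit of > 1000 nM in this assay, at which 1 of the 4 values shown sits. On this amine nitrogen, 1-methylpiperidin-4-yl in place of cyclohexylmethyl, with the same count of heavy atoms, gives an at least 470-fold higher number from compound 3 to compound 4 (2.67 log units; beyond the scatter), so the position distinguishes sharply between two groups of equal size by that count. The other steps, an at least 21-fold higher number from compound 2 to compound 4 (1.32 log units; beyond the scatter) and an at least 90-fold higher number from compound 1 to compound 4 (1.95 log units; beyond the scatter), extend the range of the series beyond what the three earlier amines showed.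

Still open, on these data alone, is whether the ring nitrogen or the lost methylene link matters more: cyclohexyl set directly on the amine nitrogen and (1-methylpiperidin-4-yl)methyl would separate the two.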